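Replacing a distal aryl group: expected acid dissociation

The source may report more compounds than this note shows. Statements on the series, on what has been measured and on what is new or still open speak of the compounds shown alone.

Measured compounds:
compound 1 `COc1cccc(Oc2ccc3c(NCCCNCc4cc(F)ccc4OC)ccnc3c2)c1` gives 9.28
compound 2 `COc1ccc(F)cc1CNCCCNc1ccnc2cc(Cc3ccc(F)cc3Cl)ccc12` gives 9.47

In a physicochemical assay for acid dissociation, compound 2 gives 9.47. Among the compounds with values here, the only other measured compound is compound 1, which gives 9.28, and the step of a number 0.19 log units higher from compound 1 to compound 2 (within the scatter) shows that the two numbers are within the usual scatter of each other. Compound 1 and compound 2 differ only at one aromatic carbon of the shared core, where compound 1 carries a 3-methoxyphenoxy group and compound 2 carries a 2-chloro-4-fluorobenzyl group.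

Compound 3 `COc1ccc(-c2ccc3c(NCCCNCc4cc(F)ccc4OC)ccnc3c2)cc1` is not yet measured. It differs from compound 2 at the same place: 4-methoxyphenyl in place of 2-chloro-4-fluorobenzyl on an aromatic carbon. Within the data shown here, the one measured step that bears on this change, a number 0.19 log units higher from compound 1 to compound 2 (within the scatter), exchanged a group at this very position and moved the number by less than the scatter. On that basis the step from compound 2 to compound 3 is expected to be small, with no clear direction: a number 0.07 log units lower from compound 2 to compound 3 (within the scatter). Compound 3 is therefore estimated to give 9.4, with a range from 9 to 9.8.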

Compound 3, acid dissociation constant: 9.47
Estimate against measurement, compound 3: 0.07 log units below; the measured number falls inside the stated range.
By their numbers in this assay, from the lowest: compounds 1, 2 and 3 (each within the scatter of the next).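

In this assay, the step of no change at the digits printed from compound 2 to compound 3 (within the scatter) comes from placing 4-methoxyphenyl where 2-chloro-4-fluorobenzyl stood, and the step of a number 0.19 log units higher from compound 1 to compound 3 (within the scatter) comes from placing the same group where 3-methoxyphenoxy stood. Three different groups have now been compared on this aromatic carbon, and all of their numbers lie within the scatter of one another, even though this change removes the chlorine and fluorine atoms and brings in a hydrogen-bond acceptor. No measurement here explains why the number holds steady across these groups.

All three groups contain a six-membered aromatic ring of carbon only and carry no net charge, so these compounds cannot show whether a group of a different kind on this carbon, such as a piperidine amine or a carboxylic acid, would shift the number beyond the scatter. From the compounds shown here alone, how the number would respond to a change elsewhere in the molecule, such as a longer chain in place of the present one, also remains open.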